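The compounds below may be only part of what the source reports. "The series", "measured", "known", "first", "only" and "open" are said of these compounds alone.

Measured so far:
Compound 1, `Cn1c(-c2ccccc2)cc2onc(-c3cccnc3)c2c1=O`: in a functional assay on CHO cells for antagonist activity at metabotropic glutamate receptor 7 (Rattus norvegicus), read by FLIPR and calcium flux (a lower number here means a stronger inhibitor, a higher number a weaker inhibitor), compound 1 gives 240 nM.
Compound 2, `COc1ccc(-c2cc3onc(-c4ccccc4)c3c(=O)n2C)cc1`: in this assay compound 2 gives 22 nM.

Among the compounds with values here, compound 2 stands lowest of the two numbers in this assay; its only neighbour is compound 1, whose number is higher by a margin beyond the scatter. Within the data shown here, the two compounds differ in more than one place, so no single step connects them; their two values show only that compound 2 is the stronger inhibitor of the pair.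

The next compound is compound 3, `CN(C)c1ccc(-c2cc3onc(-c4ccccc4)c3c(=O)n2C)cc1`. It differs from compound 2 in one place: dimethylamino in place of methoxy on an aromatic carbon. Among the measured compounds shown here, no measured pair differs only here, so there is no precedent for what this change does in this assay. In the absence of such a precedent, the expected step is a 1.1-fold higher number from compound 2 to compound 3 (0.06 log units; within the scatter), that is none beyond the scatter in either direction. Compound 3 is accordingly estimated at 25 nM in this assay, with an expected range from 8 nM to 80 nM.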

Compound 3, half-maximal inhibitory concentration: 140 nM
Compound 3: the middle estimate sits 5.6-fold (0.75 log units) below what was measured, outside the stated range (above it).
By their numbers in this assay, from the lowest: compound 2; then compounds 3 and 1 (each within the scatter of the next).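

In this assay, within the data shown here, this is the first step that can be read at a single place: dimethylamino in place of methoxy on an aromatic carbon, para to a large group, gives a 6.4-fold higher number from compound 2 to compound 3 (0.80 log units; beyond the scatter). The position is therefore not indifferent to the group it carries, since the change lies beyond the scatter even though the counts of hydrogen-bond donors and acceptors and the net charge stay the same, with only the heavy-atom count rising from 2 to 3. No measurement at hand bears on why the number rises.

A single step cannot show whether the rise follows the size of the group or some other feature of dimethylamino, nor whether the same change would have a similar effect with different groups elsewhere on the core. Also open, from the compounds shown here alone, is how this position responds to an ethoxy group, a hydroxyl, a primary amine or a fluorine atom, any of which would help show how far methoxy is particular at this place.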